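The source may report more compounds than this note shows. Statements on the series, on what has been measured and on what is new or still open speak of the compounds shown alone.

Measured compounds:
compound 1 `CS(=O)(=O)c1cc(N)c2ncccc2c1[N+](=O)[O-]`, in an assay for binding affinity to Neuropeptide Y receptor type 1 (Homo sapiens), read by radioligand binding; on this read-out lower numbers stand for stronger inhibition and higher numbers for weaker inhibition: > 10000 nM
compound 2 `Nc1cc(NS(=O)(=O)c2ccccc2)c([N+](=O)[O-])c2cccnc12`, in this assay: > 10000 nM

The value of compound 2 in this assay is a limit of the assay and not a number. The value of compound 1 in this assay is likewise a limit. For the measured compounds named here, both results sit at the limit of > 10000 nM in this assay, at which 2 of the 2 values shown sit, so nothing within the two measured compounds can be ordered or sized; compound 1 is known only to lie at that limit, and no step between the measured compounds is available.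

Compound 3 `Nc1cc(S(=O)(=O)c2ccc(Cl)cc2)c([N+](=O)[O-])c2cccnc12` is not yet measured. It differs from compound 1 by 4-chlorophenyl in place of methyl on a sulfonyl sulfur. Going by the values given here, with both measured values at the limit, no measured step gives a direction for this change. The expectation is that the step from compound 1 to compound 3 in this assay, a step that the limit leaves unreadable from compound 1 to compound 3, stays within the scatter, with compound 3 most likely remaining at the same limit. Compound 3 is therefore estimated at 15000 nM in this assay, with a range from 3000 nM to 80000 nM, and a number below the limit is considered less likely than a further limit result.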

Compound 3, inhibition constant: 1750 nM
For compound 3 the middle estimate is 8.6-fold (0.93 log units) above the measured one; the whole stated range lies above it.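

In this assay, for the compounds shown here, 4-chlorophenyl in place of methyl on a sulfonyl sulfur gives an at least 5.7-fold lower number from compound 1 to compound 3 (0.75 log units; beyond the scatter), so the result at this position responds to the group carried there, something the earlier compounds, both without a readable number, could not show. Compound 1 gives > 10000 nM, which is a limit of the assay and not a number. Going by these compounds alone, the size of the step is therefore only a minimum, and compound 3 is the only one of the three compounds with a measured number, the other two resting at the limit: the limit of > 10000 nM in this assay, at which 2 of the 3 values shown sit.

As far as these compounds go, whether the aromatic ring alone or the chlorine on it carries the step stays open, as does the result for a plain phenyl or a 4-methoxyphenyl on the same sulfonyl sulfur. Also open, from the compounds shown here alone, is whether a change elsewhere on the shared core, such as an acetamide in place of the amine, would move the number of compound 3 in this assay in either direction.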